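Swapping a benzothiophene for bromophenyl on a thioether arm

A few compounds are considered here, and "the series" means these few. Any claim that something is new, unique, unknown or untested is made for them only; others in the source may bear on it.

In a toxicity assay on GES1 cells (Homo sapiens) for inhibition, read by MTT assay, with a stated time of 72 h (on this read-out higher numbers stand for weaker inhibition and lower numbers for stronger inhibition), compound 1, `Cc1cc(N2CC[C@@H](C)[C@@H](N(C)c3ncnc4[nH]ccc34)C2)n2nc(SCc3csc4ccc(Cl)cc34)nc2n1`, gives > 100000 nM; this reading is a limit of the assay rather than a measured number. Compound 2, `CCc1cc(N2CC[C@@H](C)[C@@H](N(C)c3ncnc4[nH]ccc34)C2)n2ncnc2n1`, gives > 100000 nM in this assay, again a limit and not a number. Compound 1 therefore stands at the limit of > 100000 nM in this assay, at which 2 of the 2 values shown sit, so no ordering between the two measured compounds can be drawn from what is shown. Going by the values given here, no pair of measured compounds differs in a single place, so no measured step is available to lean on.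

Compound 3, `Cc1cc(N2CC[C@@H](C)[C@@H](N(C)c3ncnc4[nH]ccc34)C2)n2nc(SCc3ccc(Br)cc3)nc2n1`, is the untested compound. It differs from compound 1 by 4-bromophenyl in place of 5-chloro-1-benzothiophen-3-yl on a saturated chain carbon bound to a sulfur. Because compound 1 sits at the limit of > 100000 nM in this assay, at which 2 of the 2 values shown sit, any step from compound 1 to compound 3 in this assay can only be guessed at: the expectation is that compound 3 stays close to the same limit, with no step beyond the scatter of repeated measurements, which is what the estimated step that the limit leaves unreadable from compound 1 to compound 3 expresses. Compound 3 is thus expected to give about 150000 nM in this assay, within an estimated range from 40000 nM to 600000 nM, and most likely the assay would again report only a limit.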

Compound 3, half-maximal inhibitory concentration: 55600 nM
For compound 3 the middle estimate is 2.7-fold (0.43 log units) above the measured one; the range from low to high includes it.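

In this assay compound 3 gives 55600 nM, a measured number rather than a limit, which shows that a compound with this shared core and a thioether arm can register on these cells within the range of the assay. Placing 4-bromophenyl in place of 5-chloro-1-benzothiophen-3-yl on a saturated chain carbon bound to a sulfur gives an at least 1.7-fold lower number from compound 1 to compound 3 (0.25 log units; that floor lies within the scatter); this figure is only a floor, so the change may be larger, but the floor alone does not establish a step beyond the scatter. The other two compounds remain uninformative on any ordering, as both sit at the same limit: the limit of > 100000 nM in this assay, at which 2 of the 3 values shown sit.

The change swaps the ring system and the halogen together, so these compounds cannot show whether the loss of the fused ring, the loss of chlorine or the gain of bromine accounts for the measurable reading. Also open, as far as these compounds go, is how a plain benzyl group without bromine, or a longer chain between the sulfur and the ring, would read in this assay.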